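A few compounds are considered here, and "the series" means these few. Any claim that something is new, unique, unknown or untested is made for them only; others in the source may bear on it.

Measured in a functional assay on U-87MG ATCC cells for antiproliferative activity against U-87 MG (Homo sapiens), read by MTT assay, with a stated time of 48 h; on this read-out higher numbers stand for weaker inhibition and lower numbers for stronger inhibition:
compound 1, `COc1ccc(-c2nc(SCC(=O)c3sc(-c4ccccc4)nc3C)nc(N)c2C#N)cc1`: 14000 nM
compound 3, `Cc1nc(-c2ccccc2)sc1C(=O)CSc1nc(N)c(C#N)c(-c2ccc(Cl)cc2)n1`: 10800 nM
compound 2, `COc1ccc(-c2nc(C)c(C(=O)CSc3nc(-c4ccc(Cl)c(Cl)c4)c(C#N)c(=O)[nH]3)s2)cc1`: 68500 nM

Compound 1 stands second highest of the three numbers in this assay. Compound 3 is nearest, with a 1.3-fold lower number from compound 1 to compound 3 (0.11 log units; within the scatter), a change on the aromatic ring attached to the shared core. Within the data shown here, compound 2 gives the highest number; no single-point step links it to compound 1, so the two values are only set side by side.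

Compound 4, `COc1ccc(-c2nc(SCC(=O)c3sc(-c4ccc(Cl)cc4)nc3C)nc(N)c2C#N)cc1`, differs from compound 1 by chloro in place of hydrogen on an aromatic carbon. Among the measured compounds shown here, the one measured step that bears on a chloro change is a 1.3-fold lower number from compound 1 to compound 3 (0.11 log units; within the scatter), and it stayed within the scatter. On that basis no step beyond the scatter is expected, a 1.2-fold lower number from compound 1 to compound 4 (0.07 log units; within the scatter). Compound 4 is estimated at 12000 nM, expected between 5000 nM and 30000 nM.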

Compound 4, half-maximal inhibitory concentration: 10600 nM
Beside the measured number, compound 4's estimate is 1.1-fold (0.05 log units) above it; the measured number falls inside the stated range.
By their numbers in this assay, from the lowest: compounds 4, 3 and 1 (each within the scatter of the next); then compound 2.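

In this assay, phenyl to 4-chlorophenyl gives a 1.3-fold lower number from compound 1 to compound 4 (0.12 log units; within the scatter), so this position carries a chloro with no step beyond the scatter. The earlier chloro step replaced methoxy on a different ring; here chloro replaces hydrogen, and this step also stays within the scatter. No measured evidence bears on this result.

Open, as far as these compounds go, is whether an amine or a carboxylic acid at this same place would give a step beyond the scatter. Also open, from the compounds shown here alone, is how a longer chain in place of the methyl would read.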